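The compounds below may be only part of what the source reports. "The series", "measured", "known", "first", "only" and "open" are said of these compounds alone.

Compound 1 `CCOC(=O)[C@H](CCC(=O)O)NC(=O)c1ccc(CNc2nc3cc(N)cc(N)c3nc2-c2ccccc2)cc1` and compound 2 `Nc1cc(N)c2nc(-c3ccccc3)c(NCc3ccc(Cl)c(Cl)c3)nc2c1` share one core and differ in the group attached to it. In a functional assay on K562 cells (Homo sapiens) for inhibition, read by sulforhodamine B assay, with a stated time of 48 h (on this read-out lower numbers stand for stronger inhibition of growth and higher numbers for weaker inhibition of growth), compound 2 gives 17800 nM. For compound 1 this assay reports only a limit, < 100000 nM. Compound 3 `COc1ccc(CNc2nc3cc(N)cc(N)c3nc2-c2ccccc2)cc1OC` likewise shows only a limit in this assay, < 100000 nM. The step that the limit leaves unreadable from compound 2 to compound 3 cannot be read because it ends at the limit (the limit of < 100000 nM in this assay, at which 2 of the 3 values shown sit). Compound 4 `COc1cc(CNc2nc3cc(N)cc(N)c3nc2-c2ccccc2)cc(OC)c1OC` differs from compound 3 by methoxy in place of hydrogen on an aromatic carbon. Going by the values given here, no measured step covers such a change, and the one step touching compound 3 is unreadable. The step that the limit leaves unreadable from compound 3 to compound 4 is therefore estimated as no change beyond the scatter. Compound 4 is expected at 50000 nM, within 15000 nM to 100000 nM, quite possibly again reported only as a limit.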

Compound 4, concentration for total growth inhibition: < 50200 nM
Compound 4: a limit, no number; the forecaster's own chance of this, stated with the estimate: 60%; the middle value is on the limit's open side.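

Compound 3 and compound 4 each carry only a limit, and the step between them cannot be read. As far as these compounds go, whether the added methoxy changes growth inhibition at all, and by how much, stays open.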